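Removing the 2-hydroxyethyl group from compound 2

This account rests on a few compounds, and the source may have more. Where it says the series, first, only, none or still open, it means among the compounds named here.

Two compounds have been measured in a functional assay on HT-29 cells (Homo sapiens) for antiproliferative activity, read by MTT assay, with a stated time of 72 h (on this read-out higher numbers stand for weaker inhibition and lower numbers for stronger inhibition), so far:
Compound 1 `COc1cc2c(Oc3ccc(Nc4nccc5[nH]cc(-c6ccc(F)cc6)c(=O)c45)cc3F)ccnc2cc1OCCO` gives 2900 nM
Compound 2 `O=c1c(-c2ccc(F)cc2)c[nH]c2ccnc(Nc3ccc(Oc4ccnc5cc(OCCO)ccc45)c(F)c3)c12` gives 5500 nM

Among the measured compounds shown here, compound 2 stands level with the only other measured compound, the sole step being a 1.9-fold higher number from compound 1 to compound 2 (0.28 log units; within the scatter) for hydrogen in place of methoxy on an aromatic carbon. Compound 3 `O=c1c(-c2ccc(F)cc2)c[nH]c2ccnc(Nc3ccc(Oc4ccnc5cc(O)ccc45)c(F)c3)c12` derives from compound 2 by one change (hydrogen in place of 2-hydroxyethyl on an oxygen on an aromatic ring), hydrogen in place of 2-hydroxyethyl on an oxygen on an aromatic ring. For the measured compounds named here, no measured step touches this group, so that single step, itself within the scatter, is only an indirect guide. In this assay no step beyond the scatter is therefore expected, and the estimate is a 1.1-fold higher number from compound 2 to compound 3 (0.04 log units; within the scatter) with no firm direction. Compound 3 is expected at 6000 nM (estimated range 2000 nM to 18000 nM).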

Compound 3, half-maximal inhibitory concentration: 5900 nM
For compound 3 the middle estimate is 1.0-fold (0.01 log units) above the measured one; measured number inside the range.
By their numbers in this assay, from the lowest: compounds 1, 2 and 3 (each within the scatter of the next, the first and the last beyond it).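

In this assay the step from the 2-hydroxyethoxy group to hydroxy is a 1.1-fold higher number from compound 2 to compound 3 (0.03 log units; within the scatter) and so stays within the scatter. Among the compounds shown here, this is the first measured step at this oxygen on an aromatic ring, and it shows that in this pair the 2-hydroxyethyl group can give way to hydrogen with compound 2 and compound 3 standing level. Nothing at hand accounts for this result.

The compounds shown leave open whether a longer chain, a 2-aminoethyl group or a carboxylic acid on this oxygen would also stand level in this assay or would move the number beyond the scatter. They also leave open what a methyl group on this oxygen, or the loss of the oxygen itself, would do.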